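The source may hold more compounds than are shown below. What is called first, only, known or untested is meant among the compounds shown, and "the series" means these compounds.

The three compounds share one core and differ only in the ring attached to a nitrogen on that core. Compound 1 `COc1cc2ncnc(Nc3ccc(F)c(Cl)c3)c2cc1OCCCCC(=O)Nc1ccc(S(N)(=O)=O)cc1` carries a 3-chloro-4-fluorophenyl there. In a functional assay on NCI-H1975 cells (Homo sapiens) for antiproliferative activity, read by MTT assay, with a stated time of 72 h (on this read-out higher numbers stand for weaker inhibition and lower numbers for stronger inhibition), compound 1 gives 35600 nM. Compound 2 `COc1cc2ncnc(Nc3cccc(F)c3)c2cc1OCCCCC(=O)Nc1ccc(S(N)(=O)=O)cc1` carries a 3-fluorophenyl instead. In this assay compound 2 reaches only the limit of the test, > 40000 nM, not a number. Compound 3 `COc1cc2ncnc(Nc3ccc(F)cc3)c2cc1OCCCCC(=O)Nc1ccc(S(N)(=O)=O)cc1` carries a 4-fluorophenyl. In this assay compound 3 likewise reaches only a limit, > 40000 nM. Compound 2 thus stands at the limit of > 40000 nM in this assay, at which 2 of the 3 values shown sit, with no number of its own.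

The unmeasured compound 4 `COc1cc2ncnc(Nc3ccc(F)c(Br)c3)c2cc1OCCCCC(=O)Nc1ccc(S(N)(=O)=O)cc1` differs from compound 2 by 3-bromo-4-fluorophenyl in place of 3-fluorophenyl on a nitrogen on an aromatic ring. Going by the values given here, two measured steps bear on this: an at least 1.1-fold higher number from compound 1 to compound 2 (0.05 log units; that floor lies within the scatter) and an at least 1.1-fold higher number from compound 1 to compound 3 (0.05 log units; that floor lies within the scatter), both running into the limit, so their true size is unknown; the step that the two limits leave unreadable from compound 2 to compound 3. Compound 4 carries a 3-bromo-4-fluorophenyl, as compound 1 carries a 3-chloro-4-fluorophenyl. Compound 4 is therefore expected to give about 30000 nM in this assay, between 10000 nM and 80000 nM. The expected step of an at least 1.3-fold lower number from compound 2 to compound 4 (0.12 log units; that floor lies within the scatter) would be a return to roughly where compound 1 sits, with a real chance of another limit.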

Compound 4, half-maximal inhibitory concentration: 31600 nM
Compound 4: the middle estimate sits 1.1-fold (0.02 log units) below what was measured; low and high end bracket the measured number.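

In this assay, bromo in place of chloro on the aromatic carbon gives a 1.1-fold lower number from compound 1 to compound 4 (0.05 log units; within the scatter), so the two halogens cannot be told apart here. Bromo in place of hydrogen gives an at least 1.2-fold lower number from compound 3 to compound 4 (0.10 log units; that floor lies within the scatter), and the whole ring change gives an at least 1.2-fold lower number from compound 2 to compound 4 (0.10 log units; that floor lies within the scatter), so neither step proves a real gain from the bromo group, and their true size is unknown. The comparison compounds give only a limit, not a number: the limit of > 40000 nM in this assay, at which 2 of the 4 values shown sit.

From the compounds shown here alone, it remains open whether a methyl, a nitrile or a trifluoromethyl group in place of the bromo in compound 4 would give a number clearly apart from that of compound 1. A shorter or longer chain on the shared core is equally untested by these compounds.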